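A few compounds are considered here, and "the series" means these few. Any claim that something is new, unique, unknown or untested is made for them only; others in the source may bear on it.

Measured in a functional assay on SK-MEL-28 cells (Homo sapiens) for inhibition, read by MTT assay, with a stated time of 72 h; a higher number here means a weaker inhibitor of growth, a lower number a stronger inhibitor of growth:

- Compound 1 `C=C1CCCC(C)(C)[C@@H]1CC/C(C)=C/C(=O)NC(=N)NC(=O)C=C(C)C`: 60500 nM
- Compound 2 `CC(C)=CC(=O)NC(=N)NC(=O)C=C(C)C`: > 100000 nM (a limit, not a number)

A concentration for half-maximal growth inhibition tells how much compound is needed to halve cell growth, so a smaller figure means a stronger compound. Compound 2 reads > 100000 nM in this assay, and this is a limit of the assay and not a number. Compound 2 therefore stands at the limit of > 100000 nM in this assay, at which 1 of the 2 values shown sits. Compound 1, by contrast, gives a true number, 60500 nM.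

Compound 3 `CC(C)=CCC/C(C)=C/C(=O)NC(=N)NC(=O)C=C(C)C` is compound 2 with one change: 3-methylbut-2-en-1-yl in place of hydrogen on a saturated chain carbon bound to a double-bonded chain carbon. A 3-methylbut-2-en-1-yl group takes the place of hydrogen on a saturated chain carbon bound to a double-bonded chain carbon.

Among the compounds with values here, no measured step between closely matched compounds exists here, so any expectation is loose. Within the data shown here, the only numerical guide is compound 1 at 60500 nM, which suggests a modest gain at best. The expected change is small and towards stronger inhibition, estimated as an at least 1.1-fold lower number from compound 2 to compound 3 (0.07 log units; that floor lies within the scatter). For compound 3 the estimate is 85000 nM, with an expected range of 40000 nM to 150000 nM.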

Compound 3, concentration for 50% growth inhibition: 53400 nM
Estimate against measurement, compound 3: 1.6-fold (0.20 log units) above; measured number inside the range.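

Putting 3-methylbut-2-en-1-yl in place of hydrogen on a saturated chain carbon bound to a double-bonded chain carbon gives, in this assay, an at least 1.8-fold lower number from compound 2 to compound 3 (0.27 log units; that floor lies within the scatter). Compound 2 reads only as a limit of the assay, not a number, so that step is a floor and not a full measure of the change: the limit of > 100000 nM in this assay, at which 1 of the 3 values shown sits.

The real size of the step may be larger, but its floor lies within the usual scatter, so this pair alone does not establish a gain. What this pair adds is that with this open chain, which holds no ring, compound 3 gives a true number, 53400 nM.

On these data alone, it remains open whether this reading depends on the 3-methylbut-2-en-1-yl group itself or would follow from other groups at this place, such as a saturated hexyl chain, or a chain ending in an amine or a carboxylic acid. Also open, as far as these compounds go, is the true number for compound 2, which would be needed to fix the size of the step.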